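This account rests on a few compounds, and the source may have more. Where it says the series, first, only, none or still open, it means among the compounds named here.

Compound 1, `N/C(=N\NC(=S)N1CCCCCC1)c1ccccn1`: 67%
Compound 2, `Cc1cccc(/C(N)=N/NC(=S)N2CCCCCC2)n1`: 45.8%
Compound 3, `Cc1cccc(/C(N)=N/NC(=S)N2CCCC2)n1`: 67.6%

The three compounds share a thiosemicarbazone skeleton and were tested in a functional assay on A-431 cells (Homo sapiens) for cytotoxicity, read by MTT assay, with a stated time of 72 h, tested at 10 uM (a higher number here means more inhibition of growth at the concentration tested, a lower number less inhibition of growth), where compound 1 gives 67%. Compound 2 carries a methyl group on its ring and gives 45.8%. Compound 1 differs from compound 2 by hydrogen in place of methyl on an aromatic carbon, and this step gave a number 21.2 percentage points higher from compound 2 to compound 1 (beyond the scatter). Compound 3 keeps the methyl but has a smaller ring on the thiourea side and gives 67.6%; how its core differs from that of compound 2 is not broken down here. Its value and that of compound 1 lie within the scatter of each other.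

Compound 4, `N/C(=N\NC(=S)N1CCCC1)c1ccccn1`, has not yet been measured. It differs from compound 3 by hydrogen in place of methyl on an aromatic carbon, the same change as that from compound 2 to compound 1, at the same place. A step in the same direction is expected, a number 6.4 percentage points higher from compound 3 to compound 4 (within the scatter), but a smaller one, because a number 21.2 percentage points higher from compound 2 to compound 1 (beyond the scatter) rests on a single pair and compound 3 already sits high. Compound 4 is therefore expected to give about 74%, likely between 58% and 88%.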

Compound 4, percent growth inhibition at one concentration: 77.2%
Compound 4: the middle estimate sits 3.2 percentage points below what was measured; measured number inside the range.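

In this assay, putting hydrogen in place of the methyl on the ring gives a number 9.6 percentage points higher from compound 3 to compound 4 (within the scatter), so the change points the same way on this second core as on the first, although this step alone cannot be told apart from ordinary repeat-to-repeat variation. Two pairs of compounds do not show that the change would behave the same way on any other core, and they do not fix a single size for it. Set side by side, the two steps cannot be said to differ, so the data give no sign that the core alters the effect of this change, though they cannot rule it out either: the same change on two cores in this assay, a number 21.2 percentage points higher (beyond the scatter) from compound 2 to compound 1 and a number 9.6 percentage points higher (within the scatter) from compound 3 to compound 4, 11.6 percentage points apart, within the scatter of two such steps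

The compounds shown leave open what other groups at this place on the ring would do, for example an amine, a methoxy group or a longer chain such as propyl, as only methyl and hydrogen appear there. Also open, going by these compounds, is whether the same pattern would hold at other concentrations or in other cell lines.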